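Replacing a benzamidomethyl arm with a bromophenylethenyl group

This account rests on a few compounds, and the source may have more. Where it says the series, first, only, none or still open, it means among the compounds named here.

Of the compounds shown here, three sharing one core have been measured in a functional assay on HCT-116 cells (Homo sapiens) for cytotoxicity, read by MTT assay, with a stated time of 72 h; on this read-out higher numbers stand for weaker inhibition and lower numbers for stronger inhibition. Compound 1 `CN1CCN(Cc2nnc(-c3cc(S(N)(=O)=O)c(SCc4ccccc4)cc3Cl)o2)CC1` gives 75000 nM, compound 2 `[N-]=[N+]=NCc1nnc(-c2cc(S(N)(=O)=O)c(SCc3ccccc3)cc2Cl)o1` gives 100000 nM, and compound 3 `NS(=O)(=O)c1cc(-c2nnc(CNC(=O)c3ccccc3)o2)c(Cl)cc1SCc1ccccc1` gives 42000 nM. Compound 3 thus carries the lowest of the three numbers, but its gap to compound 1 is small, a 1.8-fold lower number from compound 1 to compound 3 (0.25 log units; within the scatter), and only the gap to compound 2 clears the scatter, a 2.4-fold lower number from compound 2 to compound 3 (0.38 log units; beyond the scatter). The remaining step, a 1.3-fold higher number from compound 1 to compound 2 (0.12 log units; within the scatter), is likewise within the scatter, so the whole set sits close together at weak inhibition.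

Compound 4 `NS(=O)(=O)c1cc(-c2nnc(/C=C/c3ccc(Br)cc3)o2)c(Cl)cc1SCc1ccccc1` differs from compound 3 in one place: 2-(4-bromophenyl)ethenyl in place of benzamidomethyl on an aromatic carbon. Among the compounds with values here, none of the measured steps bears directly on this change, since each of them swapped a group on a saturated chain carbon while keeping the benzamidomethyl-type arm, whereas here the arm itself is exchanged for a group of a different kind. What the measured steps do show is that changes at this position have moved this assay by at most the modest 2.4-fold lower number from compound 2 to compound 3 (0.38 log units; beyond the scatter). Compound 4 is therefore expected to stay in the same weak range, with an estimated step of a 1.1-fold lower number from compound 3 to compound 4 (0.02 log units; within the scatter) and an estimate of 40000 nM, between 10000 nM and 120000 nM.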

Compound 4, half-maximal inhibitory concentration: 15000 nM
For compound 4 the middle estimate is 2.7-fold (0.43 log units) above the measured one; low and high end bracket the measured number.
By their numbers in this assay, from the lowest: compound 4; then compounds 3, 1 and 2 (each within the scatter of the next, the first and the last beyond it).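

Exchanging the whole arm on the aromatic carbon of the five-membered ring lowers the number in this assay (a 2.8-fold lower number from compound 3 to compound 4 (0.45 log units; beyond the scatter)), so this position accepts 2-(4-bromophenyl)ethenyl, which counts no hydrogen-bond donor or acceptor, in place of benzamidomethyl, which counts one of each. The steps from the other two arms are larger (a 6.7-fold lower number from compound 2 to compound 4 (0.82 log units; beyond the scatter); a 5.0-fold lower number from compound 1 to compound 4 (0.70 log units; beyond the scatter)), and with all three steps beyond the scatter, compound 4 is the most potent of the four compounds in this read-out, which the earlier swaps on the saturated chain carbon had not reached. The data offer no measurement that accounts for this gain.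

The compounds shown leave open whether the bromine, the ethenyl link or the loss of the amide carries the step, a question that a plain phenylethenyl arm or a saturated ethyl link to the same bromophenyl ring could help separate. They also leave open how a carboxylic acid or an amine on that phenyl ring would read here, and whether the gain holds when the rest of the shared core changes.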